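The source may hold more compounds than are shown below. What is called first, only, known or untested is meant among the compounds shown, and "the series" means these compounds.

Compound 1 `O=C(S[C@@]12CC[C@H](O)[C@@H]1C(=O)NC2=O)c1ccccc1Cl` and compound 2 `O=C(S[C@@]12CC[C@H](O)[C@@H]1C(=O)NC2=O)c1ccccc1` share one core. In a functional assay on RAW264.7 cells (Mus musculus) for inhibition, read by Griess assay, with a stated time of 24 h (a higher number here means a weaker inhibitor, a lower number a stronger inhibitor), compound 1 gives 127000 nM and compound 2 gives 72400 nM. The change between them, (hydrogen in place of chloro on an aromatic carbon), makes the step of a 1.8-fold lower number from compound 1 to compound 2 (0.24 log units; within the scatter). Compound 3 `CC(=O)OC1CC[C@]2(SC(=O)c3ccccc3Cl)C(=O)NC(=O)[C@H]12` is built on a different core, and the difference between the two cores is not broken down here. In this assay compound 3 gives 101000 nM, a number that lies within the scatter of both compound 1 and compound 2. Compound 4 `CC(=O)OC1CC[C@]2(SC(=O)c3ccccc3)C(=O)NC(=O)[C@H]12` has not yet been measured. It differs from compound 3 by hydrogen in place of chloro on an aromatic carbon, the same change that turned compound 1 into compound 2, at the same place on the same kind of ring. Because the step of a 1.8-fold lower number from compound 1 to compound 2 (0.24 log units; within the scatter) stayed within the scatter, the corresponding step in this assay is expected to be of like size, a 1.7-fold lower number from compound 3 to compound 4 (0.24 log units; within the scatter), an expectation resting on that single measured pair alone. For compound 4 in this assay the estimate is 58000 nM, expected to fall between 25000 nM and 135000 nM.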

Compound 4, half-maximal inhibitory concentration: 64300 nM
Estimate against measurement, compound 4: 1.1-fold (0.04 log units) below; low and high end bracket the measured number.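

Going from 2-chlorophenyl to phenyl gives, in this assay, a 1.6-fold lower number from compound 3 to compound 4 (0.20 log units; within the scatter), and the same change on the other core reads much alike: the same change on two cores in this assay, a 1.8-fold lower number (0.24 log units; within the scatter) from compound 1 to compound 2 and a 1.6-fold lower number (0.20 log units; within the scatter) from compound 3 to compound 4, 1.1-fold (0.05 log units) apart, within the scatter of two such steps. In these two pairs, then, the step keeps its size from one core to the other, so the earlier pair was a fair guide to the later one. Yet each step lies within the scatter, so neither pair shows that the change does anything real to the number, and two pairs cannot show how it would behave on any further core in this series.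

The compounds shown hold only chloro or hydrogen at this place on the aromatic ring, so it remains open what a group such as an amine, a methoxy or a carboxylic acid would do there. From the compounds shown here alone, it also remains open whether a group of that kind would give a step that rises clear of the scatter and whether such a step would carry from one core to the other.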